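Removing one methyl from compound 2

A few compounds are considered here, and "the series" means these few. Any claim that something is new, unique, unknown or untested is made for them only; others in the source may bear on it.

Measured in an ADME assay on MDCK cells (Canis lupus familiaris) for permeability; a lower number here means that the compound crosses the layer more slowly, a higher number that the compound crosses the layer faster:
Compound 1 `CN[C@H](CNc1cc(F)c(S(=O)(=O)Nc2ncc(F)s2)cc1Cl)CC1CCC1`: 5 10^-6 cm/s
Compound 2 `CN[C@H](CNc1cc(F)c(S(=O)(=O)Nc2ncc(F)s2)cc1Cl)CC1(C)CC1`: 7 10^-6 cm/s

Compound 2 stands at 7 10^-6 cm/s, within the scatter of compound 1 in this assay. Compound 3 `CN[C@H](CNc1cc(F)c(S(=O)(=O)Nc2ncc(F)s2)cc1Cl)CC1CC1` differs from it by hydrogen in place of methyl on a saturated ring carbon. For the measured compounds named here, one measured step bears on this change, a 1.4-fold higher number from compound 1 to compound 2 (0.15 log units; within the scatter), and it stays within the scatter. Going by the values given here, no measured step removes this methyl alone, so only a small move, within the scatter, is expected. The expected step is a 1.3-fold lower number from compound 2 to compound 3 (0.10 log units; within the scatter). The estimate for compound 3 is 5.5 10^-6 cm/s, with an expected range from 3 10^-6 cm/s to 10 10^-6 cm/s.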

Compound 3, apparent permeability: 3 10^-6 cm/s
Estimate against measurement, compound 3: 1.8-fold (0.26 log units) above; low and high end bracket the measured number.
By their numbers in this assay, from the lowest: compounds 3, 1 and 2 (each within the scatter of the next, the first and the last beyond it).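

In this assay the methyl on the saturated ring carbon now counts for something: a 2.3-fold lower number from compound 2 to compound 3 (0.37 log units; beyond the scatter) is a modest step and the first here to lie beyond the scatter. Cyclopropyl in place of cyclobutyl on the chain gives a 1.7-fold lower number from compound 1 to compound 3 (0.22 log units; within the scatter) and stays within the scatter, so only compound 2 and compound 3 are separated at this position. No measured evidence accounts for the methyl step.

The compounds shown leave open what an ethyl or a trifluoromethyl on this ring carbon would give, and whether a methyl on the cyclobutyl ring would move the number the same way.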